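A few compounds are considered here, and "the series" means these few. Any claim that something is new, unique, unknown or untested is made for them only; others in the source may bear on it.

Measured so far in an ADME assay on BAEC cells (Bos taurus) for cytotoxicity, read by MTT assay, with a stated time of 2 days; a lower number here means a stronger inhibitor, a higher number a weaker inhibitor:
- compound 1 `COc1c(Br)cc(C=O)c(O)c1Br`: 806000 nM
- compound 2 `COc1c(Br)cc(C=O)c(OCc2ccccc2)c1Br`: > 12500 nM (a limit, not a number)

Compound 2 stands in the series only as a limit, > 12500 nM. Within the data shown here, no step from compound 1 can be read from these two entries, and the series holds just one true number.

Compound 3 `COC(=O)COc1c(C=O)cc(Br)c(OC)c1Br` is still to be measured in this assay. It differs from compound 2 at one place: methoxycarbonyl in place of phenyl on a saturated chain carbon bound to an oxygen on an aromatic ring. In words, this is methoxycarbonyl in place of phenyl on a saturated chain carbon bound to an oxygen on an aromatic ring.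

Among the measured compounds shown here, no measured step speaks to this change, so the expectation leans on compound 1 at 806000 nM, the only number available, and stays wide. The expected step is a step that the limit leaves unreadable from compound 2 to compound 3, towards a weaker inhibitor, and it is a rough estimate. A report as a limit alone would be no surprise. For compound 3 the estimated value is 100000 nM, with an expected range of 20000 nM to 500000 nM.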

Compound 3, half-maximal inhibitory concentration: 151000 nM
Beside the measured number, compound 3's estimate is 1.5-fold (0.18 log units) below it; the range from low to high includes it.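

Among these compounds, putting (methoxycarbonyl)methyl in place of hydrogen on an oxygen on an aromatic ring gives a 5.3-fold lower number from compound 1 to compound 3 (0.73 log units; beyond the scatter) in this assay, the first readable step at this position. A number can therefore still be read once the hydrogen on that oxygen is replaced, and this group moves it towards a stronger inhibitor by a modest amount that lies beyond the scatter. Compound 2 stands only as a limit, not a number, so the step with methoxycarbonyl in place of phenyl on the saturated chain carbon cannot be read, and neither group can be ranked against the other at this place: the limit of > 12500 nM in this assay, at which 1 of the 3 values shown sits.

With one readable substituent on this oxygen, the series does not separate an effect of the methoxycarbonyl end from that of simply replacing the hydrogen. Going by these compounds, how a carboxylic acid, a primary amine or a longer chain ending in the same ester would read at this place in this assay remains open, as does whether any of them would move the number further than this single step.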